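The source may report more compounds than this note shows. Statements on the series, on what has been measured and on what is new or still open speak of the compounds shown alone.

Working notes on the series, all read in a functional assay on SK-BR-3 cells (Homo sapiens) for antiproliferative activity, read by MTT assay, with a stated time of 72 h; a higher number here means a weaker inhibitor, a lower number a stronger inhibitor. Compound 1 `C/C=C1/[C@H](O[C@@H]2O[C@H](CO)[C@@H](O)[C@H](O)[C@H]2O)OC=C(C(=O)OC)[C@H]1CC(=O)OCc1ccco1` gives > 15000 nM, which is a limit and not a number. Compound 2 `C=C(C)CCOC(=O)C[C@@H]1C(C(=O)OC)=CO[C@@H](O[C@@H]2O[C@H](COC(C)=O)[C@@H](OC(C)=O)[C@H](OC(C)=O)[C@H]2OC(C)=O)/C1=C/C` gives > 15000 nM, also a limit. Compound 3 `C/C=C1/[C@H](O[C@@H]2O[C@H](COC(C)=O)[C@@H](OC(C)=O)[C@H](OC(C)=O)[C@H]2OC(C)=O)OC=C(C(=O)OC)[C@H]1CC(=O)OCCC1CCCCC1` gives > 15000 nM, again a limit, so the starting point of this step has no number. Within the data shown here, the series so far stands at a single value: the limit of > 15000 nM in this assay, at which 3 of the 3 values shown sit.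

The next compound is compound 4 `C/C=C1/[C@H](O[C@@H]2O[C@H](COC(C)=O)[C@@H](OC(C)=O)[C@H](OC(C)=O)[C@H]2OC(C)=O)OC=C(C(=O)OC)[C@H]1CC(=O)SCCC`, with propylsulfanyl in place of 2-cyclohexylethoxy on a carbonyl carbon.

Among the measured compounds shown here, only one measured step bears on this change, and it also alters the side chain on that carbonyl carbon: a step that the two limits leave unreadable from compound 2 to compound 3. It has no readable size to carry over. Compounds 1, 2 and 3 carry different groups on that carbonyl carbon, and none of them gives a number. On that basis no readable change is expected, and compound 4 will most likely report the same limit, although a number just inside the tested range cannot be excluded. The expected size is a step that the limit leaves unreadable from compound 3 to compound 4. The estimated value for compound 4 is 16000 nM, with an expected range from 5000 nM to 30000 nM.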

Compound 4, half-maximal inhibitory concentration: > 15000 nM
Compound 4 was reported as a limit; the forecaster's own chance of this, stated with the estimate: 75%; the middle value lies beyond the limit too.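

Compound 4 gives > 15000 nM, a limit and not a number. No new step can be read: compound 2, compound 3 and compound 4 all stand at a limit, so the steps among them have no readable size. The compounds shown leave open whether any group on that carbonyl carbon gives a number inside the tested range: the limit of > 15000 nM in this assay, at which 4 of the 4 values shown sit.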